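This account rests on a few compounds, and the source may have more. Where it says the series, first, only, none or still open, it means among the compounds named here.

Within the data shown here, in a functional assay on J82 cells (Homo sapiens) for cytotoxicity, read by colorimetric assay and MTT assay (on this read-out lower numbers stand for stronger inhibition and higher numbers for weaker inhibition), the three compounds measured so far sit level with one another. Compound 1 `COc1ccc2cc(-c3ccccc3)c(O)nc2c1` gives 10000 nM. Compound 2 `COc1cc(OC)c2cc(-c3ccccc3)c(O)nc2c1` gives 10000 nM, and compound 3 `COc1ccc(-c2cc3c(OC)cc(OC)cc3n(CC#N)c2=O)cc1` gives 10000 nM. Compound 2 therefore stands with the other two, with no gap to either beyond the scatter.

Compound 4 `COc1cc(OC)c2cc(-c3ccc(O)cc3)c(O)nc2c1` is compound 2 with its phenyl changed to 4-hydroxyphenyl, a hydroxy in place of hydrogen on an aromatic carbon. Among the measured compounds shown here, only one measured step bears on this change, and only loosely. It is no change at the digits printed from compound 1 to compound 2 (within the scatter), which places a methoxy in place of hydrogen on an aromatic carbon of the shared core and leaves the value unmoved. For the measured compounds named here, no measured step touches the phenyl itself, so the effect of a hydroxy there is untested, and that one flat step is thin support for any forecast. The expectation is therefore no shift beyond the scatter, with any departure more likely toward stronger inhibition than toward weaker. The expected step is no change at the digits printed from compound 2 to compound 4 (within the scatter). For compound 4 the estimated value is 10000 nM, with an expected range from 3000 nM to 20000 nM.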

Compound 4, half-maximal inhibitory concentration: 10000 nM
Beside the measured number, compound 4's estimate shows no gap at the digits printed, within the range that was stated.
By their numbers in this assay, from the lowest: compounds 1, 2, 3 and 4 (each within the scatter of the next).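

In this assay, placing a hydroxy on an aromatic carbon of the phenyl, para to a large group, gives no change at the digits printed from compound 2 to compound 4 (within the scatter). Among these compounds, this is the first measured change on the phenyl itself: the earlier step, no change at the digits printed from compound 1 to compound 2 (within the scatter), placed a methoxy on the shared core, and the new step shows that the phenyl to 4-hydroxyphenyl change also leaves the value flat when it is made on the core of compound 2. Nothing available bears on what lies behind this flat result.

The compounds shown leave open whether an amine or a carboxylic acid in that same place on the phenyl would shift the value away from the one compound 4 gives, 10000 nM. They also leave open whether a hydroxy on the phenyl would behave the same way on the core of compound 1, which carries one methoxy fewer, and whether a longer chain on that hydroxy oxygen would separate from the level shared so far.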